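The compounds below may be only part of what the source reports. "The series", "measured", "known", "first", "only" and "open" are said of these compounds alone.

Measured compounds:
- Compound 1, `O=C(Nc1cccc(F)c1)N[C@H]1CC[C@H](Oc2ccc(F)cc2)CC1`: 8300 nM in a functional assay on CRL2813 cells (Homo sapiens) for cytotoxicity, read by sulforhodamine B assay, with a stated time of 5 days; on this read-out higher numbers stand for weaker inhibition and lower numbers for stronger inhibition
- Compound 2, `Cc1cccc(NC(=O)N[C@H]2CC[C@H](Oc3ccc(F)cc3)CC2)c1`: 14400 nM
- Compound 3, `COc1ccc(NC(=O)N[C@H]2CC[C@H](Oc3ccc(F)cc3)CC2)cc1`: > 20000 nM

All three share one core and differ only in the aryl group on the urea nitrogen. Compound 3 stands at the weak end: its value is a limit of the assay, not a number, so only a floor is known for it (the limit of > 20000 nM in this assay, at which 1 of the 3 values shown sits). Compound 1 and compound 2 sit within the scatter of each other a 1.7-fold higher number from compound 1 to compound 2 (0.24 log units; within the scatter), while the move to compound 3 reads as an at least 2.4-fold higher number from compound 1 to compound 3 (0.38 log units; beyond the scatter) and an at least 1.3-fold higher number from compound 2 to compound 3 (0.14 log units; that floor lies within the scatter).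

Compound 4, `CSc1cccc(NC(=O)N[C@H]2CC[C@H](Oc3ccc(F)cc3)CC2)c1`, is yet to be measured. Its change from compound 3 is 3-(methylsulfanyl)phenyl in place of 4-methoxyphenyl on an amide-type nitrogen. For the measured compounds named here, the steps that bear on it are those leading into compound 3: the 4-methoxyphenyl group went with the weakest reading, whereas the 3-fluorophenyl of compound 1 and the 3-methylphenyl of compound 2 gave measurable numbers. Compound 4 carries a 3-(methylsulfanyl)phenyl group, so a return toward those numbers is expected, a lower number in this assay by a modest amount, with the possibility of another limit.

Compound 4 is therefore expected at about 12000 nM, between 5000 nM and 30000 nM. This estimate means an expected step of an at least 1.6-fold lower number from compound 3 to compound 4 (0.22 log units; that floor lies within the scatter).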

Compound 4, half-maximal inhibitory concentration: 11100 nM
Compound 4: the middle estimate sits 1.1-fold (0.03 log units) above what was measured; the measured number falls inside the stated range.
By their numbers in this assay, from the lowest: compounds 1, 4 and 2 (each within the scatter of the next). At a limit, above all of these: compound 3.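

In this assay, 3-(methylsulfanyl)phenyl on the urea nitrogen gives a number that cannot be told apart from those of the two earlier measured compounds: methylsulfanyl in place of methyl gives a 1.3-fold lower number from compound 2 to compound 4 (0.11 log units; within the scatter), and methylsulfanyl in place of fluoro gives a 1.3-fold higher number from compound 1 to compound 4 (0.13 log units; within the scatter). So across compounds 1, 2 and 4, the exchange of fluoro, methyl and methylsulfanyl on that aromatic carbon moves the reading by no more than the scatter, and this larger sulfur-bearing group adds a third example to a flat stretch that two compounds could only hint at. Compound 3 remains a limit of the assay, not a number, so the change from 4-methoxyphenyl can only be read as a floor, an at least 1.8-fold lower number from compound 3 to compound 4 (0.25 log units; that floor lies within the scatter), and the evidence for that is this: the limit of > 20000 nM in this assay, at which 1 of the 4 values shown sits.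

The compounds shown leave open whether an amine or a carboxylic acid in place of methylsulfanyl on that aromatic carbon would move the number beyond the scatter. They also leave open whether the methoxy group itself or its different place on the phenyl ring goes with the limit of compound 3, since 4-methoxyphenyl differs from the other aryl groups in both.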